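The source may hold more compounds than are shown below. What is called first, only, known or untested is meant among the compounds shown, and "the series" means these compounds.

In an ADME assay on MT4 cells (Homo sapiens) for cytotoxicity, read by MTT assay (on this read-out higher numbers stand for lower toxicity in this test and lower numbers for higher toxicity in this test), compound 3 (`Cc1ccc(N(C(=O)c2ccccc2[N+](=O)[O-])C(=S)OCCN2C(=O)c3ccccc3C2=O)cc1`) gives 100000 nM and stands highest of the three numbers measured, with compound 1 (`O=C1c2ccccc2C(=O)N1CCOC(=S)N(C(=O)c1ccccc1[N+](=O)[O-])c1ccc(Cl)cc1`) at 21000 nM and compound 2 (`O=C1c2ccccc2C(=O)N1CCOC(=S)N(C(=O)c1cccc([N+](=O)[O-])c1)c1ccc(Cl)cc1`) at 18000 nM in the same test. Compound 4 (`Cc1ccc(N(C(=O)c2cccc([N+](=O)[O-])c2)C(=S)OCCN2C(=O)c3ccccc3C2=O)cc1`) is reached from compound 3 by one exchange (3-nitrophenyl in place of 2-nitrophenyl on a carbonyl carbon) that puts 3-nitrophenyl in place of 2-nitrophenyl on a carbonyl carbon. The same exchange has been measured once, in the chloro-bearing pair, where it gave a 1.2-fold lower number from compound 1 to compound 2 (0.07 log units; within the scatter) and so stayed small. Methyl in place of chloro on an aromatic carbon gave a larger step (a 4.8-fold higher number from compound 1 to compound 3 (0.68 log units; beyond the scatter)), so compound 3 sits in a different setting, and no measured pair shows the exchange there. A step beyond the scatter is therefore not expected in this assay for this exchange. The step expected is a 1.3-fold lower number from compound 3 to compound 4 (0.10 log units; within the scatter) and it carries little weight on its own. The estimate for compound 4 is 80000 nM with an expected range of 35000 nM to 130000 nM in this test.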

Compound 4, half-maximal cytotoxic concentration: 100000 nM
Beside the measured number, compound 4's estimate is 1.3-fold (0.10 log units) below it; the range from low to high includes it.
By their numbers in this assay, from the lowest: compounds 2 and 1 (each within the scatter of the next); then compounds 3 and 4 (each within the scatter of the next).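

In this assay, the exchange of 2-nitrophenyl for 3-nitrophenyl on a carbonyl carbon now gives no change at the digits printed from compound 3 to compound 4 (within the scatter), so it reads alike on the methyl-bearing and the chloro-bearing compounds: the same change on two cores in this assay, a 1.2-fold lower number (0.07 log units; within the scatter) from compound 1 to compound 2 and no change at the digits printed (within the scatter) from compound 3 to compound 4, 1.2-fold (0.07 log units) apart, within the scatter of two such steps. Methyl in place of chloro on an aromatic carbon now has a second reading, a 5.6-fold higher number from compound 2 to compound 4 (0.74 log units; beyond the scatter), and this shows that the step holds with 3-nitrophenyl as well as with 2-nitrophenyl: the same change on two cores in this assay, a 4.8-fold higher number (0.68 log units; beyond the scatter) from compound 1 to compound 3 and a 5.6-fold higher number (0.74 log units; beyond the scatter) from compound 2 to compound 4, 1.2-fold (0.07 log units) apart, within the scatter of two such steps. Among these four compounds, the number in this assay follows methyl or chloro and not the choice of 2-nitrophenyl or 3-nitrophenyl, and none of the four goes against this.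

The compounds shown leave open whether a methoxy group in place of methyl or chloro would continue this pattern. They also leave open what an amine in place of the nitro group of the nitrophenyl would do to the number.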